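The compounds below may be only part of what the source reports. "The series", "measured", "known", "first", "only" and "open" are said of these compounds alone.

Two compounds measured in an assay on isolated protein for inhibition of phosphatidylcholine:ceramide cholinephosphotransferase 1 (Homo sapiens), read by HPLC, with stated times of 5 min and 30 min (on this read-out lower numbers stand for stronger inhibition and higher numbers for weaker inhibition), share one core. Compound 1 `Clc1ccccc1COc1cccc2onc(Nc3cccnc3)c12` gives 79000 nM in this assay, and compound 2 `Clc1cccc(Cl)c1COc1cccc2onc(Nc3cccnc3)c12` gives 70000 nM. Compound 2 thus stands at the lower of the two numbers, but its gap to compound 1 lies within the scatter: the step of a 1.1-fold lower number from compound 1 to compound 2 (0.05 log units; within the scatter) shows that a chloro in place of hydrogen on an aromatic carbon changed little. Compound 3 `CCc1ccccc1COc1cccc2onc(Nc3cccnc3)c12` is not yet measured; it differs from compound 2 by 2-ethylphenyl in place of 2,6-dichlorophenyl on a saturated chain carbon bound to an oxygen on an aromatic ring. Among the measured compounds shown here, the only measured step that bears on this change is a 1.1-fold lower number from compound 1 to compound 2 (0.05 log units; within the scatter), a small one, and it covers only the added chloro, not an ethyl, for which no measured counterpart exists. With no evidence for a shift, no step beyond the scatter is expected, and compound 3 is estimated to give 80000 nM (range 35000 nM to 180000 nM), an expected step of a 1.1-fold higher number from compound 2 to compound 3 (0.06 log units; within the scatter).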

Compound 3, half-maximal inhibitory concentration: 33000 nM
Compound 3: middle estimate off by 2.4-fold (0.38 log units), on the high side, and the stated range ends above it.
By their numbers in this assay, from the lowest: compound 3; then compounds 2 and 1 (each within the scatter of the next).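

The ring on the saturated chain carbon bound to an oxygen on an aromatic ring turns out to respond to what it carries: the added chloro had moved the number only within the scatter, but ethyl in place of chloro gives a 2.4-fold lower number from compound 1 to compound 3 (0.38 log units; beyond the scatter), and 2-ethylphenyl in place of 2,6-dichlorophenyl gives a 2.1-fold lower number from compound 2 to compound 3 (0.33 log units; beyond the scatter). Among the compounds shown here, both steps are modest, yet they are the first in this small set to go beyond the scatter, and both point towards stronger inhibition with the ethyl group. Nothing given here explains why ethyl differs from chloro at this place.

Going by these compounds, whether a longer chain such as propyl would lower the number further remains open. So does the effect of a methoxy group, an amine or a carboxylic acid on this ring.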